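Series notes: amino in place of the selenium group

The source may hold more compounds than are shown below. What is called first, only, known or untested is meant among the compounds shown, and "the series" means these compounds.

In a functional assay on HCT-116 cells (Homo sapiens) for inhibition, read by MTT assay, with a stated time of 48 h (on this read-out higher numbers stand for weaker inhibition and lower numbers for stronger inhibition), compound 1 (`COc1ccc(N(C)c2nc(C)nc3ccccc23)cc1C(=O)OCCC[Se]C#N`) gives 720 nM and compound 2 (`COc1ccc(N(C)c2nc(C)nc3ccccc23)cc1C(=O)OCCCC[Se]C#N`) gives 662 nM. The a 1.1-fold lower number from compound 1 to compound 2 (0.04 log units; within the scatter) stays within the scatter. Compound 3 (`COc1ccc(N(C)c2nc(C)nc3ccccc23)cc1OCC[Se]C#N`) gives 18 nM, the lowest of the three numbers, and it stands clearly apart from both others: a 40-fold lower number from compound 1 to compound 3 (1.60 log units; beyond the scatter) and a 37-fold lower number from compound 2 to compound 3 (1.57 log units; beyond the scatter).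

Compound 4 (`COc1ccc(N(C)c2nc(C)nc3ccccc23)cc1OCCN`) differs from compound 3 by one nitrogen atom in place of a group of 3 heavy atoms (1 carbon, 1 nitrogen, 1 selenium; no ring), on a saturated chain carbon, two bonds along the chain from an oxygen on an aromatic ring. Amino enters on a saturated chain carbon, two bonds along the chain from an oxygen on an aromatic ring.

Going by the values given here, no measured step isolates this change. The two large steps replace the whole group on an aromatic carbon and keep the selenium-bearing end, while the small step alters only the chain. They show that this assay can respond strongly to changes in this part of the molecule, but not what losing the end group does. With compound 3 already at 18 nM, a move towards weaker inhibition is expected, with wide uncertainty. The expected change is a 6.7-fold higher number from compound 3 to compound 4 (0.82 log units; beyond the scatter). For compound 4 the estimated value is 120 nM, with an expected range of 25 nM to 600 nM.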

Compound 4, half-maximal inhibitory concentration: 198 nM
Compound 4: middle estimate off by 1.7-fold (0.22 log units), on the low side; measured number inside the range.
By their numbers in this assay, from the lowest: compound 3; then compound 4; then compounds 2 and 1 (each within the scatter of the next).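

In this assay, going by these compounds alone, the step of an 11-fold higher number from compound 3 to compound 4 (1.04 log units; beyond the scatter) is the first to isolate the end of the chain: amino in place of the group of 3 heavy atoms (1 carbon, 1 nitrogen, 1 selenium), on a saturated chain carbon, two bonds along the chain from an oxygen on an aromatic ring, gives weaker inhibition by a large margin. Selenium is nevertheless not required for a number below those of the two selenium-bearing compounds with the carbonyl-containing chains, as a 3.3-fold lower number from compound 2 to compound 4 (0.52 log units; beyond the scatter) and a 3.6-fold lower number from compound 1 to compound 4 (0.56 log units; beyond the scatter) are both modest steps beyond the scatter, though each of these replaces the whole group on an aromatic carbon and does not isolate one feature. No evidence at hand bears on the reason for either effect.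

The compounds shown leave open whether the selenium atom or the nitrile within the departing group accounts for the large step, a question that a thiocyanate or a simple nitrile at the end of the same chain would address. They also leave open how a longer chain bearing the selenium group, or a dimethylamine or carboxylic acid at this end, would compare with compound 3 and compound 4.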